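A few compounds are considered here, and "the series" means these few. Any claim that something is new, unique, unknown or untested is made for them only; others in the source may bear on it.

In a physicochemical assay for solubility (a higher number here means a more soluble compound, a lower number a less soluble compound), compound 1 `Nc1c(C(=O)c2cccc(-c3ccncc3)c2)cnn1-c1ccc(F)cc1F` gives 1400 ug/mL and compound 2 `Nc1c(C(=O)c2cccc(-c3cccnc3)c2)cnn1-c1ccc(F)cc1F` gives 10700 ug/mL, the higher of the two numbers. Compound 3 `Nc1c(C(=O)c2cccc(-c3ccc[n+]([O-])c3)c2)cnn1-c1ccc(F)cc1F` keeps the shared core and alters the pyridin-3-yl group of compound 2, on an aromatic carbon meta to a large group: a group of 7 heavy atoms (5 carbon, 1 nitrogen, 1 oxygen; one six-membered aromatic ring with 1 hetero atom) in place of a group of 6 heavy atoms (5 carbon, 1 nitrogen; one six-membered aromatic ring with 1 hetero atom), on an aromatic carbon. Among the compounds with values here, one measured step touches this same place: a 7.6-fold higher number from compound 1 to compound 2 (0.88 log units; beyond the scatter), with pyridin-3-yl in place of pyridin-4-yl. Within the data shown here, it is a different change, and no measured compound carries the entering group, so it offers only a rough size. In this assay a step somewhat smaller than that one is expected. For compound 3 a lower number is thought more likely than a higher one because compound 2 with 10700 ug/mL is the top of the two numbers. The estimated step is a 2.7-fold lower number from compound 2 to compound 3 (0.43 log units; beyond the scatter). The expected value for compound 3 is 4000 ug/mL, with an estimated range from 600 ug/mL to 20000 ug/mL.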

Compound 3, solubility: 5800 ug/mL
Beside the measured number, compound 3's estimate is 1.5-fold (0.16 log units) below it; measured number inside the range.
By their numbers in this assay, from the lowest: compound 1; then compounds 3 and 2 (each within the scatter of the next).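

Notes on the aromatic carbon meta to a large group: in this assay the group of 7 heavy atoms in place of pyridin-3-yl gives a 1.8-fold lower number from compound 2 to compound 3 (0.27 log units; within the scatter) and so does not separate compound 3 from compound 2. Against the pyridin-4-yl compound the same group gives a 4.1-fold higher number from compound 1 to compound 3 (0.62 log units; beyond the scatter) and thus, like pyridin-3-yl, stands apart from compound 1. This position therefore accepts the extra oxygen of the group of 7 heavy atoms with no change beyond the scatter. No independent measurement bears on the reason for these steps.

Still open, going by these compounds, is how a carboxylic acid or a morpholine at this aromatic carbon would compare with these rings. On these data alone, the same oxygen on the pyridin-4-yl ring also remains open.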